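Tertiary amide on the methyloxazole core of compound 3

The compounds below may be only part of what the source reports. "The series", "measured", "known", "first", "only" and "open" are said of these compounds alone.

The series is measured in an assay on CHO cells for inhibition of bone morphogenetic protein 1 (Homo sapiens), read by fluorescence; on this read-out lower numbers stand for stronger inhibition and higher numbers for weaker inhibition. Compound 1 `O=C(C[C@@H](CCCC1CCCCC1)c1nc(C(=O)N2CCCC2)no1)NO` gives 43 nM and compound 2 `NC(=O)c1coc([C@H](CCCC2CCCCC2)CC(=O)NO)n1` gives 73 nM. Compound 3 `Cc1oc([C@H](CCCC2CCCCC2)CC(=O)NO)nc1C(N)=O` gives 17 nM, the lowest of the three numbers; its nearest neighbour is compound 1 and its furthest compound 2. Within the data shown here, the only single-point step seen so far, a 4.3-fold lower number from compound 2 to compound 3 (0.63 log units; beyond the scatter), concerns methyl in place of hydrogen on an aromatic carbon and says nothing directly about the amide.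

Compound 4 `Cc1oc([C@H](CCCC2CCCCC2)CC(=O)NO)nc1C(=O)N(C)C` differs from compound 3 by dimethylamino in place of amino on a carbonyl carbon, that is carbamoyl to dimethylcarbamoyl. Among the measured compounds shown here, no measured step changes the amide alone. Compound 1 carries a tertiary amide on a different core and shows a higher number than compound 3, but the two compounds differ in more than one place, so only their two values can be compared.

For the measured compounds named here, with no bearing step, the change is expected to cost some activity in this assay, of a size on the order of a 2.4-fold higher number from compound 3 to compound 4 (0.37 log units; beyond the scatter). Compound 4 is therefore estimated at 40 nM, within a range from 12 nM to 130 nM.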

Compound 4, half-maximal inhibitory concentration: 17 nM
The estimate for compound 4 lay 2.4-fold (0.37 log units) above the measured number, within the range that was stated.
By their numbers in this assay, from the lowest: compounds 3 and 4 (each within the scatter of the next); then compounds 1 and 2 (each within the scatter of the next).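

In this assay, among these compounds, the step of no change at the digits printed from compound 3 to compound 4 (within the scatter) is the first to change the amide alone, and it shows that carbamoyl and dimethylcarbamoyl on this carbonyl carbon cannot be told apart by this read-out. The exchange removes the hydrogen-bond donor of amino and brings in the greater heavy-atom count of dimethylamino, yet the number stays where it was, so on this core the amide hydrogen is not required to keep the value of compound 3. No measurement at hand gives a reason for this flat step.

Going by these compounds, it remains open whether the same tolerance extends to methylamino, diethylamino or morpholin-4-yl on this carbonyl carbon, or whether it ends when a carboxylic acid replaces the carbamoyl group altogether. On these data alone, it is also open whether dimethylamino would read the same on the core of compound 2, which lacks the methyl on the aromatic carbon, and compound 1 cannot settle this, as it differs from these compounds in more than one place.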